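Vinyl for ethyl at the amide carbonyl: cytotoxicity notes

The source may report more compounds than this note shows. Statements on the series, on what has been measured and on what is new or still open speak of the compounds shown alone.

Measured so far:
compound 1 `C=CC(=O)Nc1cc(Nc2ncc(Cl)c(N3CCc4sccc4C3)n2)c(OC)cc1N1CCN(C)CC1` — > 50000 nM
compound 2 `CCC(=O)Nc1ccc(OC)c(Nc2ncc(Cl)c(N3CCc4sccc4C3)n2)c1` — > 200000 nM

In a functional assay on A-431 cells (Homo sapiens) for cytotoxicity, read by MTT assay (on this read-out lower numbers stand for stronger inhibition and higher numbers for weaker inhibition), compound 2 gives > 200000 nM, which is a limit of the assay and not a number; it sits at the limit of > 200000 nM in this assay, at which 1 of the 2 values shown sits. Compound 1 likewise gives only a limit in this assay, > 50000 nM, at the limit of > 50000 nM in this assay, at which 1 of the 2 values shown sits. With both compounds at limits, compound 2 cannot be ranked against compound 1; all that is known of compound 2 is that no half-maximal concentration was reached.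

Compound 3 `C=CC(=O)Nc1ccc(OC)c(Nc2ncc(Cl)c(N3CCc4sccc4C3)n2)c1` differs from compound 2 in one place: vinyl in place of ethyl on a carbonyl carbon. Going by the values given here, no measured step bears on that exchange, and the only other compound carrying the vinylcarbonyl group, compound 1, is itself at a limit. The step of an at least 1.3-fold lower number from compound 2 to compound 3 (0.12 log units; that floor lies within the scatter) is therefore expected to stay within the usual scatter rather than to move clearly in either direction. For compound 3 the estimate in this assay is 150000 nM, with a range from 20000 nM to 600000 nM, and a limit rather than a number is the more likely outcome.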

Compound 3, half-maximal inhibitory concentration: 90900 nM
Estimate against measurement, compound 3: 1.7-fold (0.22 log units) above; measured number inside the range.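

In this assay, going by these compounds alone, vinyl in place of ethyl on a carbonyl carbon gives an at least 2.2-fold lower number from compound 2 to compound 3 (0.34 log units; beyond the scatter) and so shows that this exchange can be read, with compound 3 the only one of the three compounds to give a number and not a limit. Going by these compounds, compound 2 gives only a limit, so that step is a floor and its true size is unknown: the limit of > 200000 nM in this assay, at which 1 of the 3 values shown sits.
On these data alone, the step between compound 1 and compound 3 cannot be read, so the effect of 4-methylpiperazin-1-yl in place of hydrogen on an aromatic carbon remains unknown.

As far as these compounds go, whether the change at the carbonyl carbon is specific to vinyl remains open, since a longer chain such as 1-butenyl or a chloromethyl group on that carbon could be compared with it. A morpholine in place of 4-methylpiperazin-1-yl would test the other site on the same core.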